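Working notes on compound 2 and the proposed compound 4

This account rests on a few compounds, and the source may have more. Where it says the series, first, only, none or still open, it means among the compounds named here.

In a functional assay on HeLa cells (Homo sapiens) for antiproliferative activity, read by MTT assay, with a stated time of 72 h (a lower number here means a stronger inhibitor, a higher number a weaker inhibitor), compound 2 `CCCCc1cn(C[C@H](O)[C@H]2OC(=O)C(OCc3ccccc3)=C2OCc2ccccc2)nn1` gives 18100 nM. Among the three measured compounds it holds the lowest number, but its nearest neighbour, compound 1 `O=C1O/C(=C\Cn2cc(-c3ccc(Br)cc3)nn2)C(OCc2ccccc2)=C1OCc1ccccc1`, gives 24300 nM in this assay, a gap within the scatter, so no order between compound 2 and compound 1 is claimed. Compound 3 `O=C1O/C(=C\Cn2cc(-c3cccc(O)c3)nn2)C(OCc2ccccc2)=C1OCc1ccccc1` gives 74800 nM in this assay and sits clearly higher. Among the compounds with values here, the one measured step in the set, a 3.1-fold higher number from compound 1 to compound 3 (0.49 log units; beyond the scatter), concerns an aromatic substituent on another part of the molecule and does not touch the saturated chain altered here.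

Compound 4 `Cc1ccc(S(=O)(=O)NCc2cn(C[C@H](O)[C@H]3OC(=O)C(OCc4ccccc4)=C3OCc3ccccc3)nn2)cc1` differs from compound 2 by ((4-methylphenyl)sulfonyl)amino in place of propyl on a saturated chain carbon bound to an aromatic carbon. Within the data shown here, no measured pair reports this exchange, and none alters the chain attached to the shared core, so there is no direct guide. The measured compounds span only a modest range in this assay, and nothing in them argues for a large move in either direction. Among the measured compounds shown here, with no measured step to lean on, the expected step of a 1.1-fold higher number from compound 2 to compound 4 (0.04 log units; within the scatter) in this assay is none beyond the scatter, with the range widened to allow for the size of the entering group. Compound 4 is therefore estimated at 20000 nM in this assay, between 7000 nM and 60000 nM.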

Compound 4, half-maximal inhibitory concentration: 14400 nM
Beside the measured number, compound 4's estimate is 1.4-fold (0.14 log units) above it; the measured number falls inside the stated range.
By their numbers in this assay, from the lowest: compounds 4, 2 and 1 (each within the scatter of the next); then compound 3.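

Within the data shown here, at this position, on a saturated chain carbon bound to an aromatic carbon, ((4-methylphenyl)sulfonyl)amino in place of propyl gives a 1.3-fold lower number from compound 2 to compound 4 (0.10 log units; within the scatter) in this assay, the first measured step on this chain, and it does not separate the two compounds. The position therefore carries a group of 11 heavy atoms, with a six-membered aromatic ring of carbon only, 1 hydrogen-bond donor and 2 hydrogen-bond acceptors, in place of one of 3 heavy atoms, and the number in this assay stays within the scatter; this single pair sets no trend for other groups at the position. No data at hand offer a reason for this result.

From the compounds shown here alone, whether any part of the entering group matters alone remains open, since its ring, its sulfonyl and its amino hydrogen arrive together, and a simple amine, a carboxylic acid or a longer alkyl chain at this place would test the position with different groups. Also open, going by these compounds, is whether the same exchange would read alike on the shared core of compound 1, which carries an aryl group at the corresponding place.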